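A few compounds are considered here, and "the series" means these few. Any claim that something is new, unique, unknown or untested is made for them only; others in the source may bear on it.

Measured so far:
compound 1, `Cc1cnc(NC(=O)NCCOc2ccc(Cl)c(C)c2)s1`, 0.267 h
compound 2, `CC(C)c1cnc(NC(=O)CCCOc2ccccc2)s1`, 0.117 h

Both were run in an ADME assay on microsomes from liver (Homo sapiens) for metabolic stability, read by LC-MS, using NADPH, tested at 1 uM; a higher number here means that the compound lasts longer, a lower number that the compound disappears faster. Compound 2 stands at the lower of the two numbers: in this assay compound 2 gives 0.117 h, and compound 1 gives 0.267 h, a gap that lies beyond the usual scatter. For the measured compounds named here, no pair of measured compounds differs in only one place, so no single structural step has a measured size yet.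

The next compound, compound 3, `O=C(CCCOc1ccccc1)Nc1ncc(Cl)s1`, is not yet measured. It differs from compound 2 in one place: chloro in place of isopropyl on an aromatic carbon. Nothing in the measured pair speaks to this particular change, so the expectation for compound 3 rests on the number for compound 2 alone.

Given the value of compound 2 in this assay, 0.117 h, the step of a 1.5-fold higher number from compound 2 to compound 3 (0.19 log units; within the scatter) is expected to be small, at most modest upward, and it may well stay within the scatter. For compound 3 the half-life in this assay is estimated at 0.18 h, with a likely range from 0.08 h to 0.45 h.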

Compound 3, half-life in the Homo sapiens assay: 0.317 h
Compound 3: the middle estimate sits 1.8-fold (0.25 log units) below what was measured, within the range that was stated.
By their numbers in the Homo sapiens assay, from the lowest: compound 2; then compounds 1 and 3 (each within the scatter of the next).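

In the Homo sapiens assay the series now has its first single-place step with a measured size: chloro in place of isopropyl on an aromatic carbon, next to the ring sulfur, gives a 2.7-fold higher number from compound 2 to compound 3 (0.43 log units; beyond the scatter) and shows that the half-life is sensitive to the group at this position. In a physicochemical assay for solubility, read by nephelometry, at pH 2 (on this read-out higher numbers stand for higher solubility and lower numbers for lower solubility), compound 2 gives < 1200 nM as its reading, which is a limit of the assay and not a number. In the physicochemical assay compound 3 likewise gives < 1200 nM as its reading, again a limit.

The solubility step for this change cannot be read because both compounds stop at the same limit: the limit of < 1200 nM in the physicochemical assay, at which 2 of the 2 values shown sit. Also open, on these data alone, is whether the half-life keeps rising with other groups on this aromatic carbon, such as bromo, nitrile or methoxy, or whether the step is specific to chloro, and whether the same change would give a step of like size on the urea-linked compound 1.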